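The compounds below may be only part of what the source reports. "The series", "measured", "known", "first", "only" and "open" are said of these compounds alone.

Compound 1 `O=C(Nc1ccc(Oc2ccnc3[nH]ccc23)c(F)c1)c1nn(-c2ccc(Cl)cc2)ccc1=O` and compound 2 `COc1ccc(-n2ccc(=O)c(C(=O)Nc3ccc(Oc4ccnc5[nH]ccc45)c(F)c3)n2)cc1` share one core; compound 3 `Cn1ccc2c(Oc3ccc(NC(=O)c4nn(-c5ccc(Cl)cc5)ccc4=O)cc3)ccnc21` and compound 4 `COc1ccc(-n2ccc(=O)c(C(=O)Nc3ccc(Oc4ccnc5c4ccn5C)cc3)n2)cc1` share another, and the difference between the two cores is not broken down here. In a functional assay on PC-3 cells (Homo sapiens) for cytotoxicity, read by MTT assay, with a stated time of 72 h (on this read-out lower numbers stand for stronger inhibition and higher numbers for weaker inhibition), compound 1 gives 42500 nM. In this assay compound 2 gives 46400 nM, the change from compound 1 being (methoxy in place of chloro on an aromatic carbon), and the step reads a 1.1-fold higher number from compound 1 to compound 2 (0.04 log units; within the scatter). For compound 3 the assay reports only a limit, > 60000 nM. Compound 4 carries the same change, (methoxy in place of chloro on an aromatic carbon), at the same place. The step expected here, a step that the limit leaves unreadable from compound 3 to compound 4, rests on the earlier one, a 1.1-fold higher number from compound 1 to compound 2 (0.04 log units; within the scatter), which stayed inside the scatter. Compound 4 is therefore expected to give roughly 80000 nM, somewhere between 45000 nM and 150000 nM, most likely again reported only as the limit of > 60000 nM in this assay, at which 1 of the 3 values shown sits.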

Compound 4, half-maximal inhibitory concentration: > 60000 nM
Compound 4: a limit, no number; the forecaster's own chance of this, stated with the estimate: 75%; the middle value lies beyond the limit too.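

Within the data shown here, compound 3 and compound 4 both stand only as limits, so no step between them can be read: the limit of > 60000 nM in this assay, at which 2 of the 4 values shown sit. The compounds shown leave open how the change from 4-chlorophenyl to 4-methoxyphenyl acts on the core of compound 3.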